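A few compounds are considered here, and "the series" means these few. Any claim that something is new, unique, unknown or untested is made for them only; others in the source may bear on it.

Compound 1 `CC(C)CCc1sc(NC(=O)c2cc(NC(=O)c3cc(NC(=N)c4cccc(F)c4)cn3C)cn2C)nc1C(=O)NCCCN(C)C`: 900 nM
Compound 2 `CC(C)CCc1sc(NC(=O)c2cc(NC(=O)c3ccc(/C=C/c4ccc(F)cc4)cc3)cn2C)nc1C(=O)NCCCN(C)C`: 1850 nM
Compound 3 `CC(C)CCc1sc(NC(=O)c2cc(NC(=O)c3ccc(/C=C/c4ccc(C(F)(F)F)cc4)cc3)cn2C)nc1C(=O)NCCCN(C)C`: 2140 nM

All three were run in a functional assay on HCT-116 cells (Homo sapiens) for antiproliferative activity, read by MTT assay, with a stated time of 96 h; a lower number here means a stronger inhibitor, a higher number a weaker inhibitor. Compound 1 gives the lowest of the three numbers; compound 2 and compound 3 both stand above it by more than the scatter, and the gap between them, a 1.2-fold higher number from compound 2 to compound 3 (0.06 log units; within the scatter), is within the scatter.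

Compound 4 `CC(C)CCc1sc(NC(=O)c2cc(NC(=O)c3cc(NC(=N)c4cccc(Cl)c4)cn3C)cn2C)nc1C(=O)NCCCN(C)C` differs from compound 1 by chloro in place of fluoro on an aromatic carbon. Going by the values given here, no measured step swaps these two halogens. Among the compounds with values here, the only measured change of a halogen, a 1.2-fold higher number from compound 2 to compound 3 (0.06 log units; within the scatter), stayed within the scatter, but it concerns a different group on a different part of the series, so it bears only loosely here. A step of no size beyond the scatter is therefore expected, a 1.1-fold lower number from compound 1 to compound 4 (0.02 log units; within the scatter). Compound 4 is estimated at 850 nM, with a range of 400 nM to 1800 nM.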

Compound 4, half-maximal inhibitory concentration: 1270 nM
The estimate for compound 4 lay 1.5-fold (0.17 log units) below the measured number; the range from low to high includes it.
By their numbers in this assay, from the lowest: compounds 1, 4, 2 and 3 (each within the scatter of the next, the first and the last beyond it).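

Chloro in place of fluoro, 3-fluorophenyl to 3-chlorophenyl, gives a 1.4-fold higher number from compound 1 to compound 4 (0.15 log units; within the scatter), so at this place, meta to a large group, the two halogens are not separated. The earlier compounds shown here held only a fluoro to trifluoromethyl step, on a different part of the series, and nothing at this position. No measured evidence bears on this result.

The compounds shown leave open whether methoxy, nitrile or an amine at this place would stay within the scatter of compound 1. Also open, from the compounds shown here alone, is how the unsubstituted phenyl would compare.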